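The source may hold more compounds than are shown below. What is called first, only, known or untested is meant among the compounds shown, and "the series" means these compounds.

Measured compounds:
- compound 1 `Cc1ccc2[nH]c(C(=O)N3CC(=O)N(Cc4ccccc4)[C@@H](CN4CCC5(CCC5)CC4)C3)cc2c1`: 12300 nM
- compound 2 `COc1ccc2[nH]c(C(=O)N3CC(=O)N(Cc4ccccc4)[C@@H](N4[C@H](C)CCC[C@@H]4C)C3)cc2c1`: 100000 nM
- compound 3 `COc1ccc2[nH]c(C(=O)N3CC(=O)N(Cc4cccc(OC(F)F)c4)[C@@H](CN4CCCCC4)C3)cc2c1`: 26400 nM

These three compounds were examined in a physicochemical assay for solubility, read by spectrophotometry, in phosphate buffer, with a stated time of 2 h, at pH 7.4; a lower number here means a less soluble compound, a higher number a more soluble compound. Compound 2 stands highest of the three numbers: compound 3 is its nearest neighbour and sits a good deal lower, while compound 1 sits lowest, and both gaps lie beyond the usual scatter of this assay. Compound 4 `COc1ccc2[nH]c(C(=O)N3CC(=O)N(Cc4ccccc4)[C@@H](CN4CCC5(CCCC5)CC4)C3)cc2c1` has not been measured yet. Compared with compound 2, the change is a group of 11 heavy atoms (10 carbon, 1 nitrogen; one five-membered non-aromatic ring of carbon only, one six-membered non-aromatic ring with 1 hetero atom) in place of a group of 8 heavy atoms (7 carbon, 1 nitrogen; one six-membered non-aromatic ring with 1 hetero atom), on a saturated ring carbon. Among the measured compounds shown here, no direct step between measured compounds matches this change, so the expectation rests on the surrounding values. Compound 1, which carries a related spiro-ring group on the same position of the shared core, gives 12300 nM in this assay, and compound 3, with a piperidin-1-ylmethyl group there, gives 26400 nM. The step from compound 2 to compound 4 is therefore expected to be a fall beyond the scatter, a 6.7-fold lower number from compound 2 to compound 4 (0.82 log units; beyond the scatter). Compound 4 is estimated at 15000 nM, with a likely range from 5000 nM to 45000 nM.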

Compound 4, solubility: 5000 nM
The estimate for compound 4 lay 3.0-fold (0.48 log units) above the measured number; low and high end bracket the measured number.
By their numbers in this assay, from the lowest: compound 4; then compound 1; then compound 3; then compound 2.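

In this assay, replacing the 2,6-dimethylpiperidin-1-yl group with the larger group holding a five-membered ring of carbon only and a six-membered ring with one hetero atom gives a 20-fold lower number from compound 2 to compound 4 (1.30 log units; beyond the scatter) on this saturated ring carbon. Among the compounds shown here, this is the first readable step at this position, and it shows that the number depends strongly on the group placed there, even though both groups have the same hydrogen-bond donor and acceptor counts and no net charge. No available measurement explains the fall.

Because the two groups differ in both size and ring make-up, the compounds shown leave open which of these differences matters more. From the compounds shown here alone, it also remains open whether a morpholine or a carboxylic acid at this position would keep the number close to that of compound 2.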